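Fluoro scan on the anilide ring of the pyridazinone amides

The source may report more compounds than this note shows. Statements on the series, on what has been measured and on what is new or still open speak of the compounds shown alone.

Compound 1 `Cc1cc(=O)n(-c2cccc(F)c2)nc1C(=O)Nc1ccc(Oc2ncnc3sccc23)cc1` and compound 2 `Cc1cc(=O)n(-c2ccc(F)c(F)c2)nc1C(=O)Nc1ccc(Oc2ncnc3sccc23)cc1` share a core and differ only on the pendant aryl of the pyridazinone. In a functional assay on MCF7 cells (Homo sapiens) for cytotoxicity, read by MTT assay, with a stated time of 72 h (on this read-out higher numbers stand for weaker inhibition and lower numbers for stronger inhibition), compound 1 gives 27200 nM, and in the same assay compound 2 gives 16100 nM. Among the compounds with values here, the step of a 1.7-fold lower number from compound 1 to compound 2 (0.23 log units; within the scatter) is the only measured change so far, and it lies within the scatter, so compound 2 is the lower of the two numbers without being separable from compound 1.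

Compound 3 `Cc1cc(=O)n(-c2ccc(F)c(F)c2)nc1C(=O)Nc1ccc(Oc2ncnc3sccc23)c(F)c1` carries the change (fluoro in place of hydrogen on an aromatic carbon), this time on the anilide ring, ortho to a large group and meta to a large group. Within the data shown here, no measured step covers this ring; the only step that bears on it at all is the fluoro-for-hydrogen step from compound 1 to compound 2, which stayed within the scatter. The expectation for this assay is therefore no movement beyond the scatter, in either direction, the estimated step being a 1.2-fold lower number from compound 2 to compound 3 (0.06 log units; within the scatter). Compound 3 is expected to give about 14000 nM, with a range from 5000 nM to 40000 nM.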

Compound 3, half-maximal inhibitory concentration: 20600 nM
Compound 3: middle estimate off by 1.5-fold (0.17 log units), on the low side; the measured number falls inside the stated range.
By their numbers in this assay, from the lowest: compounds 2, 3 and 1 (each within the scatter of the next).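

In this assay, fluoro in place of hydrogen on the anilide ring, ortho to a large group and meta to a large group, gives a 1.3-fold higher number from compound 2 to compound 3 (0.11 log units; within the scatter). Within the data shown here, this is the first reading at this position, and it shows that the ring can carry the added fluoro without a step that stands clear of the scatter. Together with a 1.7-fold lower number from compound 1 to compound 2 (0.23 log units; within the scatter) on the pendant aryl, fluoro in place of hydrogen has now been read on two different rings of the shared core, and in compounds 1, 2 and 3 neither step goes beyond the scatter, with no compound here going against that. Nothing measured bears on the cause of this result.

Fluoro is the only group shown at this position, and it remains open whether a methoxy group or an amine on the same carbon would give a step beyond the scatter in this assay. Also open, as far as these compounds go, is whether a larger change on the pendant aryl, such as a carboxylic acid in place of a fluoro, would separate from compounds 1, 2 and 3 in that assay.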